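The source may report more compounds than this note shows. Statements on the series, on what has been measured and on what is new or still open speak of the compounds shown alone.

Compound 1, `Cc1c(CN2CCCC2)cc(-c2ccc(Cl)cc2)n1Nc1ccnc2cc(Cl)ccc12`: 4.06
Compound 2, `Cc1ccc(-c2cc(CN3CCCC3)c(C)n2Nc2ccnc3cc(Cl)ccc23)cc1`: 3.91

Among the measured compounds shown here, in a physicochemical assay for lipophilicity, at pH 5.2 (a higher number here means a more lipophilic compound, a lower number a more polar compound), compound 2 stands within the scatter of compound 1, the only other measured compound; the step of a number 0.15 log units lower from compound 1 to compound 2 (within the scatter) is not a real difference. Compound 3 `Cc1c(CN2CCCC2)cc(-c2ccc(N)cc2)n1Nc1ccnc2cc(Cl)ccc12` differs from compound 2 by amino in place of methyl on an aromatic carbon. For the measured compounds named here, no measured step exchanges methyl for amino, and the single step at hand, chloro to methyl, says nothing about this exchange. Compound 3 is nonetheless expected to give about 2.5 in this assay, with a likely range from 1.8 to 3.2. The expected step is a number 1.41 log units lower from compound 2 to compound 3 (beyond the scatter).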

Compound 3, distribution coefficient: 2.03
Estimate against measurement, compound 3: 0.47 log units above; the measured number falls inside the stated range.
By their numbers in this assay, from the lowest: compound 3; then compounds 2 and 1 (each within the scatter of the next).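

Chloro and methyl on this carbon could not be told apart, so the position might have seemed indifferent to what it carries. In this assay amino shows otherwise, with a number 1.88 log units lower from compound 2 to compound 3 (beyond the scatter) and a number 2.03 log units lower from compound 1 to compound 3 (beyond the scatter) as its steps, both large whichever group it replaces. Nothing at hand accounts for the size of this drop. From the compounds shown here alone, whether a hydroxyl, a methoxy or an acetamide on the same carbon would move the number as far remains open, and so does whether a dimethylamino group would.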